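The compounds below may be only part of what the source reports. "The series", "measured", "known", "first", "only" and "open" are said of these compounds alone.

Working notes on the series, measured in a functional assay on PC-3 cells (Homo sapiens) for antiproliferative activity, read by MTT assay, with a stated time of 48 h; on this read-out higher numbers stand for weaker inhibition and lower numbers for stronger inhibition:

- compound 1 `C=CCN(C)C(=O)c1ccc(C(CC)(CC)c2ccc(OCCC(O)(CC)CC)c(C)c2)n1CC`: 12800 nM
- compound 2 `CCC(C)C(NC(=O)c1ccc(C(CC)(CC)c2ccc(OCCC(O)(CC)CC)c(C)c2)n1CC)C(=O)OC`: > 50000 nM, a limit of the assay and not a number
- compound 3 `CCn1c(C(=O)NC(CC(=O)O)C(=O)OC)ccc1C(CC)(CC)c1ccc(OCCC(O)(CC)CC)c(C)c1`: 11200 nM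

Within the data shown here, compound 3 is one of only two compounds with a numerical value, and it stands level with compound 1 within the scatter: a 1.1-fold lower number from compound 1 to compound 3 (0.06 log units; within the scatter).

Compound 4 `CCn1c(C(=O)NC(CO)CCO)ccc1C(CC)(CC)c1ccc(OCCC(O)(CC)CC)c(C)c1` replaces the amide substituent of compound 3: a group of 6 heavy atoms (4 carbon, 2 oxygen; no ring) in place of a group of 9 heavy atoms (5 carbon, 4 oxygen; no ring), on an amide-type nitrogen. The group that enters is 3-hydroxy-1-(hydroxymethyl)propyl, on an amide-type nitrogen.

Among the measured compounds shown here, three measured steps bear on this change. Compound 1 and compound 3 give a 1.1-fold lower number from compound 1 to compound 3 (0.06 log units; within the scatter), whereas the two larger steps both involve compound 2: an at least 3.9-fold higher number from compound 1 to compound 2 (0.59 log units; beyond the scatter) and an at least 4.4-fold lower number from compound 2 to compound 3 (0.64 log units; beyond the scatter). Compound 4 lacks the sec-butyl of compound 2, so the smaller step is the closer guide, although a modest loss remains possible.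

In this assay, the expected step is small and within the scatter: a 1.3-fold higher number from compound 3 to compound 4 (0.13 log units; within the scatter). The estimated value for compound 4 is 15000 nM, with an expected range of 6000 nM to 40000 nM.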

Compound 4, half-maximal inhibitory concentration: 8760 nM
Compound 4: middle estimate off by 1.7-fold (0.23 log units), on the high side; measured number inside the range.
By their numbers in this assay, from the lowest: compounds 4, 3 and 1 (each within the scatter of the next). At a limit, above all of these: compound 2.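

In this assay, 3-hydroxy-1-(hydroxymethyl)propyl on the amide-type nitrogen leaves the number level with that of compound 3, a 1.3-fold lower number from compound 3 to compound 4 (0.11 log units; within the scatter), so a group without a carbonyl holds the same level here. The same holds against the shared core's amide in compound 1, a 1.5-fold lower number from compound 1 to compound 4 (0.16 log units; within the scatter), which puts compounds 1, 3 and 4 level despite three different groups on the carbonyl carbon. Compound 2 stays apart, an at least 5.7-fold lower number from compound 2 to compound 4 (0.75 log units; beyond the scatter), and its value is a limit of the assay and not a number: the limit of > 50000 nM in this assay, at which 1 of the 4 values shown sits.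

Going by these compounds, whether an amine or a phenyl ring on this nitrogen would move the number beyond the scatter remains open. So does whether a single hydroxyl on a longer chain would hold the level reached by compound 4.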